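Ester Side-Chain Variation on a Dihydropyridine Calcium Channel Antagonist

This account rests on a few compounds, and the source may have more. Where it says the series, first, only, none or still open, it means among the compounds named here.

Three compounds share one core and differ only in the ester side chain. Compound 1 `COC(=O)C1=C(C)NC(C)=C(C(=O)OCC(C)[N+](=O)[O-])C1c1cccc([N+](=O)[O-])c1` was tested in a functional assay on HEK293 cells for antagonist activity at Voltage-dependent L-type calcium channel subunit alpha-1C (Oryctolagus cuniculus), read by FLIPR (a higher number here means a weaker inhibitor, a lower number a stronger inhibitor), and gives 108 nM. Compound 2 `COC(=O)C1=C(C)NC(C)=C(C(=O)OCc2cc([N+](=O)[O-])cc([N+](=O)[O-])c2)C1c1cccc([N+](=O)[O-])c1` gives 55 nM in this assay, and compound 3 `COC(=O)C1=C(C)NC(C)=C(C(=O)OC2Cc3ccccc3C2)C1c1cccc([N+](=O)[O-])c1` gives 72 nM. On these numbers compound 3 sits among the others rather than apart from them: compound 2 at 55 nM and compound 1 at 108 nM both lie within the scatter of compound 3.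

Compound 4 `COC(=O)C1=C(C)NC(C)=C(C(=O)OCCCCc2ccccc2)C1c1cccc([N+](=O)[O-])c1` has not been measured. Its difference from compound 3 is 4-phenylbutyl in place of 2,3-dihydro-1H-inden-2-yl on an oxygen next to a carbonyl group. The two steps seen so far at this position are the change from compound 1 to compound 2, a 2.0-fold lower number from compound 1 to compound 2 (0.29 log units; within the scatter), and the change from compound 1 to compound 3, a 1.5-fold lower number from compound 1 to compound 3 (0.18 log units; within the scatter). Neither step exceeds the scatter, so the numbers give no sign that replacing one ester side chain by another moves this assay far in either direction. No step beyond the scatter is therefore expected from compound 3 to compound 4, an estimated change of a 1.0-fold higher number from compound 3 to compound 4 (0.02 log units; within the scatter). Compound 4 is expected to give about 75 nM, within a range from 30 nM to 200 nM.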

Compound 4, half-maximal inhibitory concentration: 10 nM
For compound 4 the middle estimate is 7.5-fold (0.88 log units) above the measured one, and the stated range ends above it.
By their numbers in this assay, from the lowest: compound 4; then compounds 2, 3 and 1 (each within the scatter of the next).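

Within the data shown here, with 4-phenylbutyl in place of 2,3-dihydro-1H-inden-2-yl on the oxygen next to the carbonyl group, a 7.2-fold lower number from compound 3 to compound 4 (0.86 log units; beyond the scatter) shows that this position can move this assay beyond the scatter, which none of the earlier steps did. The two other side chains also fall short of the 4-phenylbutyl group, with a 5.5-fold lower number from compound 2 to compound 4 (0.74 log units; beyond the scatter) and an 11-fold lower number from compound 1 to compound 4 (1.03 log units; beyond the scatter) setting compound 4 apart as the strongest inhibitor of the four, while the earlier three stay within the scatter of one another. The two groups in the step from compound 3 are both carbon only, with no hydrogen-bond donors or acceptors and one six-membered aromatic ring each, so the change lies in the loss of the five-membered non-aromatic ring and the open chain that enters, and no measurement at hand explains the gain.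

With a single open chain ending in a phenyl ring, the compounds shown cannot separate the length of that chain from its being open, a question that a 2-phenylethyl or a 6-phenylhexyl ester would address. They also leave open whether the gain survives an amine placed on the chain.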